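Propyl to butyl on the amide-type nitrogen

The source may hold more compounds than are shown below. What is called first, only, known or untested is meant among the compounds shown, and "the series" means these compounds.

In a functional assay on NCI-H1975 cells (Homo sapiens) for inhibition, with a stated time of 72 h (on this read-out lower numbers stand for stronger inhibition of growth and higher numbers for weaker inhibition of growth), compound 3 (`CCCN(Cc1ccc(C(=O)NO)cc1)C(=O)c1cc(C(C)C)c(O)cc1O`) gives 23700 nM, the middle of three numbers: compound 2 (`CCN(Cc1ccc(C(=O)NO)cc1)C(=O)c1cc(C(C)C)c(O)cc1O`) gives 7000 nM and compound 1 (`CCCCN(Cc1ccc(C(=O)NO)cc1)C(=O)c1cc(Cl)c(O)cc1O`) gives 66400 nM. Compound 4 (`CCCCN(Cc1ccc(C(=O)NO)cc1)C(=O)c1cc(C(C)C)c(O)cc1O`) arises from compound 3 by methyl in place of hydrogen on a saturated chain carbon, three bonds along the chain from an amide-type nitrogen, or propyl to butyl. Going by the values given here, the one measured step bearing on it is the ethyl to propyl change, a 3.4-fold higher number from compound 2 to compound 3 (0.53 log units; beyond the scatter), modest and beyond the scatter. Among the compounds with values here, compound 1 also carries butyl but differs elsewhere on the core, so it offers no clean step. A single step is thin evidence, but a further modest rise is expected, an estimated 2.1-fold higher number from compound 3 to compound 4 (0.32 log units; beyond the scatter). For compound 4 the estimate is 50000 nM, with an expected range of 20000 nM to 120000 nM.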

Compound 4, concentration for 50% growth inhibition: 23600 nM
The estimate for compound 4 lay 2.1-fold (0.33 log units) above the measured number; the measured number falls inside the stated range.
By their numbers in this assay, from the lowest: compound 2; then compounds 4 and 3 (each within the scatter of the next); then compound 1.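

In this assay propyl to butyl on the amide-type nitrogen brings no change (a 1.0-fold lower number from compound 3 to compound 4 (0.00 log units; within the scatter)), so the rise at the previous chain step does not carry on, and the gap from ethyl to butyl remains modest (a 3.4-fold higher number from compound 2 to compound 4 (0.53 log units; beyond the scatter)). Going by these compounds alone, with butyl held fixed, isopropyl in place of chloro on an aromatic carbon gives the first clean reading at that place (a 2.8-fold lower number from compound 1 to compound 4 (0.45 log units; beyond the scatter)). No supporting data explain either result.

On these data alone, whether a longer chain such as hexyl would stay level remains open. So does whether a methoxy or bromo group at the aromatic place would follow chloro or isopropyl.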